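Swapping methyl for chloro in a weak inhibitor

The source may hold more compounds than are shown below. What is called first, only, known or untested is meant among the compounds shown, and "the series" means these compounds.

This study follows a small set of compounds built on a shared core. Compound 1 `CC(C)(C)NCc1cc(Cl)cc(Nc2nc3ccccc3[nH]2)c1O` is tested in an ADME assay on CHO cells (Cricetulus griseus) for inhibition, read by MTT assay; a lower number here means a stronger inhibitor, a higher number a weaker inhibitor; for compound 1 the assay returns only a limit, > 50000 nM. Compound 2 `CCNCc1cc(Cl)cc(Nc2nc3ccccc3n2Cc2ccc(C(F)(F)F)cc2)c1O` gives 33800 nM in this assay. Compound 3 `Cc1cc(CNC(C)(C)C)c(O)c(Nc2nc3ccccc3n2Cc2ccc(C(F)(F)F)cc2)c1` gives 30000 nM in this assay. The numbers of compound 3 and compound 2 sit within the usual scatter of each other, so the two cannot be told apart, and the remaining value is only a limit. Compound 4 `CC(C)(C)NCc1cc(Cl)cc(Nc2nc3ccccc3n2Cc2ccc(C(F)(F)F)cc2)c1O` has not yet been measured. It differs from compound 3 in one place: chloro in place of methyl on an aromatic carbon. Within the data shown here, no step between two measured compounds shows this exact change, but compound 2, which also carries chloro, gives 33800 nM close to the number of compound 3. The step from compound 3 to compound 4 in this assay is therefore expected to be small, no change at the digits printed from compound 3 to compound 4 (within the scatter), not beyond the scatter in either direction. Compound 4 is estimated at 30000 nM, within a range from 12000 nM to 70000 nM.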

Compound 4, half-maximal inhibitory concentration in the CHO assay: 36300 nM
The estimate for compound 4 lay 1.2-fold (0.08 log units) below the measured number, within the range that was stated.
By their numbers in the CHO assay, from the lowest: compounds 3, 2 and 4 (each within the scatter of the next). At a limit, above all of these: compound 1.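

In the CHO assay the new compound adds three steps: a 1.2-fold higher number from compound 3 to compound 4 (0.08 log units; within the scatter), a 1.1-fold higher number from compound 2 to compound 4 (0.03 log units; within the scatter) and an at least 1.3-fold lower number from compound 1 to compound 4 (0.13 log units; that floor lies within the scatter); the first two show that neither change at its position can be told from the scatter here, and the third rests on a limit, so it gives only a floor. In a physicochemical assay for solubility, read by HPLC, measured as kinetic solubility, with a stated time of 24 h, at pH 6.5 (a lower number here means a less soluble compound, a higher number a more soluble compound), compound 3 gives 50000 nM. The same swap of methyl for chloro stays within the scatter in the CHO assay, but in the physicochemical assay it gives a clear step: an at least 10-fold lower number from compound 3 to compound 4 (1.00 log units; beyond the scatter). In the physicochemical assay compound 4 gives < 5000 nM, which is a limit of the assay and not a number.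

As far as these compounds go, how far compound 4 truly lies from compound 3 in the physicochemical assay stays open. So does how a methoxy group or a fluorine atom at this position, para to the hydroxy group, would read in either assay.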